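This account rests on a few compounds, and the source may have more. Where it says the series, first, only, none or still open, it means among the compounds named here.

Measured compounds:
compound 1 `O=[N+]([O-])c1ccc(CSc2nnc(-c3ccncc3)n2-c2ccccc2)cc1` — > 50000 nM
compound 2 `O=C(CSc1nnc(-c2ccncc2)n1-c1ccccc1)N/N=C/c1ccc([N+](=O)[O-])cc1` — 15900 nM

Going by the values given here, in a functional assay on HepG2 cells (Homo sapiens) for inhibition, read by MTT assay, with a stated time of 48 h (on this read-out higher numbers stand for weaker inhibition and lower numbers for stronger inhibition), compound 2 gives 15900 nM, the only number in the set. For compound 1 this assay reports a limit rather than a number, > 50000 nM. That value is the limit of > 50000 nM in this assay, at which 1 of the 2 values shown sits. The two measured compounds are not one change apart. Among the compounds with values here, no measured step within this assay exists to lean on.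

Compound 3 `O=C(CSc1nnc(-c2ccncc2)n1-c1ccccc1)N/N=C/c1ccccc1O` differs from compound 2 in one place: 2-hydroxyphenyl in place of 4-nitrophenyl on a carbon with a double bond to nitrogen. Within the data shown here, no measured step gives a direction for this change, so the expected step from compound 2 to compound 3 is a 1.3-fold higher number from compound 2 to compound 3 (0.10 log units; within the scatter), not beyond the usual scatter, with the uncertainty wide enough to allow a loss to the limit. Compound 3 is therefore estimated at 20000 nM in this assay, with a range from 6000 nM to 70000 nM.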

Compound 3, half-maximal inhibitory concentration: 11300 nM
Estimate against measurement, compound 3: 1.8-fold (0.25 log units) above; the measured number falls inside the stated range.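

In this assay, 2-hydroxyphenyl in place of 4-nitrophenyl on a carbon with a double bond to nitrogen gives a 1.4-fold lower number from compound 2 to compound 3 (0.15 log units; within the scatter). Going by these compounds alone, this is the first reading at this position, and it shows that two quite different groups, one with a hydrogen-bond donor and one without, cannot be told apart on this read-out. Within the data shown here, compound 1 remains a limit rather than a number and is not one change away from compound 3, so it adds no step here: the limit of > 50000 nM in this assay, at which 1 of the 3 values shown sits.

On these data alone, whether any group at this position can move the number beyond the scatter remains open. Plain phenyl would show whether either ring substituent matters at all, while a phenyl carrying an amine or a carboxylic acid, or a cyclohexyl ring, would test this place more widely.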